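A few compounds are considered here, and "the series" means these few. Any claim that something is new, unique, unknown or untested is made for them only; others in the source may bear on it.

Two related compounds have been measured in a functional assay on the whole organism (strain Wistar) for inhibition, with Rattus norvegicus as the target; a lower number here means that less compound is needed, a higher number that more compound is needed for the effect. Compound 1 `Cc1ccc2oc(=O)c(C#N)c(O)c2c1` gives 497 umol/kg, while compound 2 `Cc1ccc2c(O)c(C#N)c(=O)oc2c1` gives 52.4 umol/kg. Compound 2 therefore holds the lower of the two numbers, by a gap beyond the usual scatter, so less of it is needed for the effect. Compound 3 `Cc1cc2oc(=O)c(C#N)c(O)c2cc1C` differs from compound 2 by a methyl in place of hydrogen on an aromatic carbon, ortho to a methyl group: methyl in place of hydrogen on an aromatic carbon. Going by the values given here, no measured pair shows the effect of such a change, so any forecast is uncertain. Among the compounds with values here, with compound 1 at 497 umol/kg, the only other measured number is far higher, so a moderate rise is expected rather than a fall. The estimated change is a 2.1-fold higher number from compound 2 to compound 3 (0.32 log units; beyond the scatter), probably only a little beyond the scatter. For compound 3 the expected value is 110 umol/kg, with an estimated range from 30 umol/kg to 400 umol/kg.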

Compound 3, dose for half-maximal effect: 15.2 umol/kg
Beside the measured number, compound 3's estimate is 7.2-fold (0.86 log units) above it; the whole stated range lies above it.
By their numbers in this assay, from the lowest: compound 3; then compound 2; then compound 1.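

In this assay, a methyl in place of hydrogen, ortho to a methyl group, gives a 3.4-fold lower number from compound 2 to compound 3 (0.54 log units; beyond the scatter), so this aromatic carbon tolerates the added group and less compound is needed for the effect. The same change read from the other side gives a 33-fold lower number from compound 1 to compound 3 (1.51 log units; beyond the scatter), which places compound 3, with its two neighbouring methyl groups, lowest of the three by a margin beyond the scatter. Nothing in the data at hand explains why the number falls.

As far as these compounds go, whether the fall is specific to methyl remains open, since a longer chain such as ethyl, a methoxy group or a chlorine atom on this carbon could behave differently. Also open, from the compounds shown here alone, is whether this methyl would have the same effect without the other methyl group present.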